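The source may report more compounds than this note shows. Statements on the series, on what has been measured and on what is new or still open speak of the compounds shown alone.

Measured so far in a functional assay on HeLa cells (Homo sapiens) for inhibition, with a stated time of 72 h (on this read-out lower numbers stand for an effect already at smaller amounts and higher numbers for an effect only at larger amounts of compound), with these results:
compound 1 `COc1cc(CNCc2ccncc2)ccc1OCc1ccc(Cl)nc1` gives 400 nM
compound 2 `COc1cc(CNCc2cccnc2)ccc1OCc1ccc(Cl)nc1` gives 5000 nM

Of these two numbers, compound 2 holds the higher one at 5000 nM on this read-out. Compound 3 `COc1cc(CNCc2cccs2)ccc1OCc1ccc(Cl)nc1` has not been measured yet. It carries thiophen-2-yl in place of pyridin-3-yl on a saturated chain carbon bound to an amine nitrogen and is otherwise the same. Within the data shown here, only one measured step bears on this place. That step, a 13-fold higher number from compound 1 to compound 2 (1.10 log units; beyond the scatter) with pyridin-3-yl in place of pyridin-4-yl, was large and beyond the scatter. It gives no direction for a thiophen-2-yl group, yet compound 2 at 5000 nM stands at the top of the two numbers, so a moderate step toward a lower number is expected in this assay rather than none. The expected step is a 2.5-fold lower number from compound 2 to compound 3 (0.40 log units; beyond the scatter) by this estimate. The estimated value for compound 3 is 2000 nM within an expected range of 400 nM to 8000 nM on this reasoning.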

Compound 3, half-maximal effective concentration: 96000 nM
Estimate against measurement, compound 3: 48-fold (1.68 log units) below, and the stated range ends below it.
By their numbers in this assay, from the lowest: compound 1; then compound 2; then compound 3.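

In this assay the place on the saturated chain carbon bound to an amine nitrogen responds to more than the switch between the two pyridinyl groups: thiophen-2-yl in place of pyridin-3-yl gives a 19-fold higher number from compound 2 to compound 3 (1.28 log units; beyond the scatter) and brings no return toward lower numbers. Set against pyridin-4-yl, the same group gives a 240-fold higher number from compound 1 to compound 3 (2.38 log units; beyond the scatter), the widest gap among these compounds, so the order runs from pyridin-4-yl through pyridin-3-yl to thiophen-2-yl. Nothing available here accounts for this order.

Thiophen-2-yl changes ring size and hetero atom together, and these three compounds cannot separate the two. As far as these compounds go, how a plain phenyl ring, a furan-2-yl ring or a pyridin-2-yl group would stand at this place remains open.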